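Swapping Carboxy for Hydroxymethyl in a Low-Clearance Compound

This account rests on a few compounds, and the source may have more. Where it says the series, first, only, none or still open, it means among the compounds named here.

Compound 1 `Cc1cc(C(F)(F)F)c2cccc(OCc3c(Cl)ccc(S(=O)(=O)N4CCC[C@H]4C(N)=O)c3Cl)c2n1` in an ADME assay on microsomes (Mus musculus) for metabolic stability (on this read-out higher numbers stand for fast clearance and lower numbers for slow clearance), gives 12600 mL/min/kg
Compound 2 `Cc1cc(C(F)(F)F)c2cccc(OCc3c(Cl)ccc(S(=O)(=O)N4CCC[C@H]4C(=O)O)c3Cl)c2n1` in this assay gives 13.3 mL/min/kg

Compound 2 holds the lower of these two numbers, far from compound 1. Compound 3 `Cc1cc(C(F)(F)F)c2cccc(OCc3c(Cl)ccc(S(=O)(=O)N4CCC[C@H]4CO)c3Cl)c2n1` has not yet been measured. It carries hydroxymethyl in place of carboxy on a saturated ring carbon. Among the compounds with values here, only one measured step bears on this change: hydroxy in place of amino on a carbonyl carbon, a large step beyond the scatter (a 950-fold lower number from compound 1 to compound 2 (2.98 log units; beyond the scatter)). That step created the carboxy of compound 2, and compound 3 loses this group again, as compound 1 lacks it. One step is thin evidence, and hydroxymethyl is not the group found in compound 1. Even so, a large rise is expected in this assay (estimated: a 150-fold higher number from compound 2 to compound 3 (2.18 log units; beyond the scatter)). The expected value for compound 3 is 2000 mL/min/kg (estimated range 150 mL/min/kg to 15000 mL/min/kg).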

Compound 3, clearance: 1630 mL/min/kg
The estimate for compound 3 lay 1.2-fold (0.09 log units) above the measured number; the range from low to high includes it.
By their numbers in this assay, from the lowest: compound 2; then compound 3; then compound 1.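

Swapping carboxy for hydroxymethyl on this saturated ring carbon gives a 120-fold higher number from compound 2 to compound 3 (2.09 log units; beyond the scatter) in this assay, so a hydroxy-bearing carbon without the carbonyl does not keep the number low. Hydroxymethyl does not simply match carbamoyl either: putting it in place of that group gives a 7.7-fold lower number from compound 1 to compound 3 (0.89 log units; beyond the scatter), a modest step beside the large one. This ring carbon therefore separates all three groups in this read-out, and of the three, carboxy alone sits at the low end.

The compounds shown leave open whether other groups at this position, such as a methyl ester, a tetrazole or a longer chain ending in carboxy, would also give a low number. No measured information here accounts for the gaps between these three compounds.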